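This account rests on a few compounds, and the source may have more. Where it says the series, first, only, none or still open, it means among the compounds named here.

Among the measured compounds shown here, in a functional assay on COLO 205 cells (Homo sapiens) for inhibition, read by sulforhodamine B assay (on this read-out lower numbers stand for stronger inhibition of growth and higher numbers for weaker inhibition of growth), three related compounds have numbers so far. Compound 1 `c1ccc(-c2ccc(-c3ccc(-c4nc5ccccc5[nH]4)cc3)cc2)cc1` gives 100000 nM and stands far above the other two. Compound 3 `Cc1ccc2[nH]c(-c3ccc(-c4ccc(-c5ccccc5)cc4)cc3)nc2c1` gives 2560 nM and compound 2 `Cc1ccc2[nH]c(-c3ccc(-c4ccc(-c5cccc(Cl)c5)cc4)cc3)nc2c1` gives 2780 nM so these two sit level at the low end of the numbers.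

Compound 4 `Cc1ccc2[nH]c(-c3ccc(-c4ccc(-c5ccc(O)cc5)cc4)cc3)nc2c1` is compound 3 with hydroxy in place of hydrogen on an aromatic carbon, para to a large group. The difference counts as hydroxy in place of hydrogen on an aromatic carbon and reads as phenyl to 4-hydroxyphenyl.

For the measured compounds named here, two measured steps bear on this change, and both only loosely. Methyl in place of hydrogen on an aromatic carbon gave a 39-fold lower number from compound 1 to compound 3 (1.59 log units; beyond the scatter) which is large, yet that is a different group in a different place. Hydrogen in place of chloro on an aromatic carbon gave a 1.1-fold lower number from compound 2 to compound 3 (0.04 log units; within the scatter) and lies within the scatter, and this nearer guide points to a small step here.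

Going by the values given here, no measured compound carries hydroxy, so the direction stays open and the range must be wide. The estimated step is a 1.3-fold lower number from compound 3 to compound 4 (0.11 log units; within the scatter) and none beyond the scatter is expected. Compound 4 is estimated at 2000 nM with an expected range from 600 nM to 7000 nM in this read-out.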

Compound 4, concentration for 50% growth inhibition: 100000 nM
Compound 4: the middle estimate sits 50-fold (1.70 log units) below what was measured; measured number above the stated range.
By their numbers in this assay, from the lowest: compounds 3 and 2 (each within the scatter of the next); then compounds 1 and 4 (each within the scatter of the next).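

In this assay, the phenyl of compound 3 proves sensitive to what it carries: hydroxy in place of hydrogen, para to a large group, gives a 39-fold higher number from compound 3 to compound 4 (1.59 log units; beyond the scatter), which means much weaker inhibition of growth. The 3-chlorophenyl of compound 2 had stood within the scatter of that phenyl, yet 4-hydroxyphenyl in its place gives a 36-fold higher number from compound 2 to compound 4 (1.56 log units; beyond the scatter), so a change that makes no visible difference with one group on this ring says little about the next group. Nothing measured here explains why hydroxy produces so large a step.

The compounds shown leave open whether a methoxy group or an amine at this same place would give a number as high as that of compound 4 or stay level with compound 3. They also leave open whether hydroxy elsewhere on this ring would produce a step of the same size, and whether a carboxylic acid would behave like hydroxy or differently.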